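This account rests on a few compounds, and the source may have more. Where it says the series, first, only, none or still open, it means among the compounds named here.

Compound 3 `CCCN(CCC)c1c(Cl)ccc2nc(Nc3c(C)cc(Cl)cc3OC)n(C)c12` carries a single chloro on the shared core. In an assay on CHO cells for displacement of a labelled ligand from corticotropin-releasing factor receptor 1 (Homo sapiens), read by scintillation counting, with a stated time of 1.5 h (on this read-out higher numbers stand for weaker inhibition and lower numbers for stronger inhibition), compound 3 reaches only the limit of the assay, > 10000 nM, so no number is known for it. The other two measured members do give numbers: compound 1 `CCCN(CCC)c1c(Cl)cc(Cl)c2nc(Nc3c(C)cc(Cl)cc3OC)n(C)c12` shows 170 nM in this assay, and compound 2 `CCCN(CCC)c1ccc(C#N)c2nc(Nc3c(C)cc(Cl)cc3OC)n(C)c12` shows 14 nM. Compound 4 `CCCN(CCC)c1cccc2nc(Nc3c(C)cc(Cl)cc3OC)n(C)c12` has not been measured; it differs from compound 3 by hydrogen in place of chloro on an aromatic carbon. Among the measured compounds shown here, the one measured step of the same kind is an at least 58-fold higher number from compound 1 to compound 3 (1.76 log units; beyond the scatter), which points to a much higher number when a chloro is taken off this part of the core, though the size of that step is itself open at the top because compound 3 sits at the limit of > 10000 nM in this assay, at which 1 of the 3 values shown sits. On that basis the further removal in compound 4 is expected to give no recovery beyond the scatter, and the outcome is most likely another limit. Compound 4 is estimated at 15000 nM, within 3000 nM to 60000 nM, with the step from compound 3 expected as a step that the limit leaves unreadable from compound 3 to compound 4.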

Compound 4, half-maximal inhibitory concentration: 14 nM
Compound 4: middle estimate off by 1100-fold (3.03 log units), on the high side, outside the stated range (below it).
By their numbers in this assay, from the lowest: compounds 2 and 4 (each within the scatter of the next); then compound 1. At a limit, above all of these: compound 3.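

Taking off the chloro ortho to a dipropylamino group gives an at least 710-fold lower number from compound 3 to compound 4 (2.85 log units; beyond the scatter) in this assay, so on this core hydrogen at that place is compatible with a low number. The same kind of change therefore runs in opposite directions at the two places on the ring: the earlier chloro removal gave an at least 58-fold higher number from compound 1 to compound 3 (1.76 log units; beyond the scatter). Hydrogen in place of cyano at that other place gives no change at the digits printed from compound 2 to compound 4 (within the scatter), so in this pair the cyano brings no readable gain over hydrogen.

From the compounds shown here alone, the true size of the step from compound 3 stays open, as the value of compound 3 is a limit and not a number: the limit of > 10000 nM in this assay, at which 1 of the 4 values shown sits. Also open is whether a fluoro, a methoxy or an amine at the place ortho to a dipropylamino group would keep the number of compound 4.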